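The source may report more compounds than this note shows. Statements on the series, on what has been measured and on what is new or still open speak of the compounds shown alone.

Compound 3, `N#Cc1ccc(Cn2cncc2CNc2ccc(C(=O)NCc3ccccc3)c(-c3ccccc3)c2)cc1`, belongs to a set of three compounds that share one core and differ only in the group on the amide-type nitrogen. In a functional assay on NIH3T3 cells (Mus musculus) (on this read-out lower numbers stand for an effect already at smaller amounts and higher numbers for an effect only at larger amounts of compound), compound 3 gives no number but a limit, > 10 uM. Compound 1, `COC(=O)[C@H](CCSC)NC(=O)c1ccc(NCc2cncn2Cc2ccc(C#N)cc2)cc1-c1ccccc1`, carries a 1-(methoxycarbonyl)-3-(methylsulfanyl)propyl group at that nitrogen. In this assay compound 1 likewise gives only a limit, > 10 uM. Compound 2, `CC(C)NC(=O)c1ccc(NCc2cncn2Cc2ccc(C#N)cc2)cc1-c1ccccc1`, carries an isopropyl group there. For compound 2 this assay also reports only a limit, > 10 uM. The steps between these three, a step that the two limits leave unreadable from compound 1 to compound 2, a step that the two limits leave unreadable from compound 1 to compound 3 and a step that the two limits leave unreadable from compound 2 to compound 3, cannot be read in size or direction because of the limit of > 10 uM in this assay, at which 3 of the 3 values shown sit.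

Compound 4, `N#CCNC(=O)c1ccc(NCc2cncn2Cc2ccc(C#N)cc2)cc1-c1ccccc1`, is not yet measured. It differs from compound 3 by cyano in place of phenyl on a saturated chain carbon bound to an amide-type nitrogen. All three measured steps change the same amide-type nitrogen and none of them brought a compound into the readable range, so they offer no direction for the change to compound 4. The step that the limit leaves unreadable from compound 3 to compound 4 is therefore expected to stay within the scatter. Compound 4 is expected to give about 20 uM in this assay, within a range from 8 uM to 60 uM, and most likely again only as a limit.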

Compound 4, concentration for half-maximal effect: > 10 uM
Compound 4: no number, only a limit; the forecaster's own chance of this, stated with the estimate: 80%; the middle value does not contradict the limit.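

Compound 4 again gives only a limit in this assay, so its steps from compound 1, compound 2 and compound 3 cannot be read in size or direction, because all the values stop at that limit: (the limit of > 10 uM in this assay, at which 4 of the 4 values shown sit). The compounds shown leave open whether any group on the amide-type nitrogen of the shared core gives a readable number in this assay.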